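A few compounds are considered here, and "the series" means these few. Any claim that something is new, unique, unknown or untested is made for them only; others in the source may bear on it.

In a functional assay on HT-29 cells (Homo sapiens) for antiproliferative activity, read by sulforhodamine B assay, with a stated time of 48 h (on this read-out lower numbers stand for stronger inhibition and higher numbers for weaker inhibition), compound 1 `CCc1ccccc1NS(=O)(=O)c1ccc(N2CCNC2=O)cc1` gives 240 nM, the lowest of the three numbers at hand. Compound 3 `O=C1NCCN1c1ccc(S(=O)(=O)Nc2ccccc2)cc1` gives 280 nM, the nearest value, while compound 2 `O=C1NCCN1c1ccc(S(=O)(=O)Nc2ccc(OC(F)F)cc2)cc1` gives 650 nM, the furthest. The unmeasured compound 4 `Cc1ccc(NS(=O)(=O)c2ccc(N3CCNC3=O)cc2)cc1C` differs from compound 1 in one place: 3,4-dimethylphenyl in place of 2-ethylphenyl on a sulfonamide nitrogen. Among the compounds with values here, two measured steps bear on this change. a 1.2-fold higher number from compound 1 to compound 3 (0.07 log units; within the scatter), so taking away the ethyl hardly moved the number. a 2.3-fold lower number from compound 2 to compound 3 (0.37 log units; beyond the scatter), so a group on that phenyl ring can matter modestly. Neither step tests the 3,4-dimethylphenyl itself, so only a small shift is expected, with no sure direction. Compound 4 is therefore expected to give 350 nM in this assay, likely between 150 nM and 800 nM. The expected change is a 1.5-fold higher number from compound 1 to compound 4 (0.16 log units; within the scatter).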

Compound 4, half-maximal inhibitory concentration: 230 nM
For compound 4 the middle estimate is 1.5-fold (0.18 log units) above the measured one, within the range that was stated.
By their numbers in this assay, from the lowest: compounds 4, 1 and 3 (each within the scatter of the next); then compound 2.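

In this assay, 3,4-dimethylphenyl in place of 2-ethylphenyl on a sulfonamide nitrogen gives little change (a 1.0-fold lower number from compound 1 to compound 4 (0.02 log units; within the scatter)), and 3,4-dimethylphenyl in place of phenyl gives little change as well (a 1.2-fold lower number from compound 3 to compound 4 (0.09 log units; within the scatter)). This position therefore tolerates two different arrangements of alkyl groups on the ring, as well as no group at all, while compound 2 with its difluoromethoxy group goes against any rule that all groups are tolerated. Nothing at hand explains this tolerance. Still open, from the compounds shown here alone, is how an amine or a carboxylic acid on this ring would behave. Going by these compounds, a longer chain, such as butyl, also remains untested in these compounds.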